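Aryl swap on the core: compound 3 to compound 4

A few compounds are considered here, and "the series" means these few. Any claim that something is new, unique, unknown or untested is made for them only; others in the source may bear on it.

Measured compounds in a functional assay on HT-29 cells (Homo sapiens) for antiproliferative activity, read by MTT assay, with a stated time of 72 h; on this read-out lower numbers stand for stronger inhibition and higher numbers for weaker inhibition:
compound 1, `CCNC(=O)c1cc(Oc2ccc(NC(=O)c3cc4cccnc4n(-c4ccccc4F)c3=O)cc2)ccn1`, gives 260 nM
compound 2, `CCNC(=O)c1cc(Oc2ccc(NC(=O)c3cc4cccnc4n(-c4ccc(Cl)cc4)c3=O)cc2)ccn1`, gives 330 nM
compound 3, `CCCNC(=O)c1cc(Oc2ccc(NC(=O)c3cc4cccnc4n(-c4ccccc4F)c3=O)cc2)ccn1`, gives 200 nM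

Compound 3 carries the lowest of the three numbers, but its gaps to the others are small: a 1.3-fold lower number from compound 1 to compound 3 (0.11 log units; within the scatter), and against compound 2 the separation is also within the scatter, so no order among the three can be claimed.

Compound 4, `CCCNC(=O)c1cc(Oc2ccc(NC(=O)c3cc4cccnc4n(-c4ccc(Cl)cc4)c3=O)cc2)ccn1`, is not yet measured. It differs from compound 3 by 4-chlorophenyl in place of 2-fluorophenyl on an aromatic nitrogen. The same swap has been seen once already on the shorter amide chain: a 1.3-fold higher number from compound 1 to compound 2 (0.10 log units; within the scatter), a shift that does not rise above the scatter. Nothing else in the set bears on the change. For the measured compounds named here, the expectation for compound 4 in this assay is therefore a step of about a 1.3-fold higher number from compound 3 to compound 4 (0.11 log units; within the scatter), not beyond the scatter, because the one precedent was a 1.3-fold higher number from compound 1 to compound 2 (0.10 log units; within the scatter).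

Compound 4 is thus estimated at 260 nM, with a range from 130 nM to 520 nM.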

Compound 4, half-maximal inhibitory concentration: 390 nM
Compound 4: middle estimate off by 1.5-fold (0.18 log units), on the low side, within the range that was stated.
By their numbers in this assay, from the lowest: compounds 3, 1, 2 and 4 (each within the scatter of the next).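

In this assay, 4-chlorophenyl in place of 2-fluorophenyl on the aromatic nitrogen now has a second reading, a 2.0-fold higher number from compound 3 to compound 4 (0.29 log units; within the scatter), and the two readings agree: the same change on two cores in this assay, a 1.3-fold higher number (0.10 log units; within the scatter) from compound 1 to compound 2 and a 2.0-fold higher number (0.29 log units; within the scatter) from compound 3 to compound 4, 1.5-fold (0.19 log units) apart, within the scatter of two such steps

The methyl on the saturated chain carbon also has a second reading, now with 4-chlorophenyl on the aromatic nitrogen, a 1.2-fold higher number from compound 2 to compound 4 (0.07 log units; within the scatter), and these two readings agree as well: the same change on two cores in this assay, a 1.3-fold lower number (0.11 log units; within the scatter) from compound 1 to compound 3 and a 1.2-fold higher number (0.07 log units; within the scatter) from compound 2 to compound 4, 1.5-fold (0.19 log units) apart, within the scatter of two such steps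

Neither change moves the number beyond the scatter on either core, so these four compounds show no dependence of one change on the other.

The aryl swap alters the halogen and its place together, and these compounds cannot separate the two. From the compounds shown here alone, whether a plain phenyl with no halogen on the aromatic nitrogen, or a longer chain or an amine on the amide, would give a step beyond the scatter remains open.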